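This account rests on a few compounds, and the source may have more. Where it says the series, first, only, none or still open, it means among the compounds named here.

Measured so far:

Compound 1, `N#CC1=C(N)Oc2c(c3nc4ccccc4nc3c3ccccc23)C12C(=O)N(Cc1cnnn1-c1ccc(S(N)(=O)=O)cc1)c1ccccc12` — in a functional assay on MCF7 cells (Homo sapiens) for antiproliferative activity, read by MTT assay, with a stated time of 48 h (on this read-out higher numbers stand for weaker inhibition and lower numbers for stronger inhibition), compound 1 gives > 50000 nM, which is a limit of the assay rather than a number.

Compound 2, `N#CC1=C(N)Oc2c(N)cc3nc4ccccc4nc3c2C12C(=O)N(Cc1cnnn1-c1cccc(C(F)(F)F)c1)c1ccccc12` — in this assay compound 2 gives 31600 nM.

Among the compounds with values here, compound 2 is thus the only compound of the pair with a number in this assay; the other value is a limit, as the limit of > 50000 nM in this assay, at which 1 of the 2 values shown sits, records. Its number points to weak inhibition of the growth of these breast cancer cells.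

Compound 3, `COc1cc(-n2nncc2CN2C(=O)C3(C(C#N)=C(N)Oc4c(N)cc5nc6ccccc6nc5c43)c3ccccc32)c(OC)cc1Cl`, has not yet been measured. It keeps the shared core of compound 2 and differs in a single place: 4-chloro-2,5-dimethoxyphenyl in place of 3-(trifluoromethyl)phenyl on an aromatic nitrogen. Within the data shown here, both groups are six-membered carbon rings carrying small substituents; no measured step between two compounds is available to show what such a swap does in this assay.

With compound 2 already weak and no guide from a measured step, the step from compound 2 to compound 3 is expected to be small, a 1.1-fold lower number from compound 2 to compound 3 (0.02 log units; within the scatter), no more than the usual scatter in either direction. The estimate for compound 3 in this assay is therefore 30000 nM, with a range from 10000 nM to 90000 nM, and a real chance that only a limit is reported.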

Compound 3, half-maximal inhibitory concentration: > 50000 nM
Compound 3 ended at the assay's limit; the forecaster's own chance of this, stated with the estimate: 35%; middle value at least 1.6-fold (0.22 log units) from the limit.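

In this assay, placing 4-chloro-2,5-dimethoxyphenyl in place of 3-(trifluoromethyl)phenyl on an aromatic nitrogen gives an at least 1.5-fold higher number from compound 2 to compound 3 (0.19 log units; that floor lies within the scatter), so the two hydrogen-bond acceptors that enter bring no visible gain in inhibition at this position. On these data alone, the value of compound 3 is a limit of the assay and not a number, so this step has only a floor, and the true size of the change stays unknown, whether within the usual scatter or beyond it. This is the first measured step at this position, and it leaves the compounds at the weak end of the scale, with most of the values shown sitting at the edge of what can be recorded: the limit of > 50000 nM in this assay, at which 2 of the 3 values shown sit.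

As far as these compounds go, whether a ring carrying an amine or a carboxylic acid, or a longer alkyl chain in place of the ring on this aromatic nitrogen, would bring the number clearly lower remains open. The compounds shown also leave open how much of the weak inhibition belongs to this position and how much to the shared core.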